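Removing the Quinolinylmethoxy Group from Compound 2

A few compounds are considered here, and "the series" means these few. Any claim that something is new, unique, unknown or untested is made for them only; others in the source may bear on it.

Of the compounds shown here, three built on one shared core have been measured in a functional assay for inhibition; on this read-out lower numbers stand for stronger inhibition and higher numbers for weaker inhibition. Compound 1 `CC(C)(C)c1cc(-c2cc(=O)c3ccc(OCC(=O)O)cc3o2)cc(C(C)(C)C)c1O` gives two entries, 3000 nM; 100 nM (2 entries), which lie far apart (the several entries of compound 1 in this assay, 3000 nM; 100 nM (2 entries)). Compound 2 `CC(C)(C)c1cc(-c2cc(=O)c3ccc(OCc4ccc5ccccc5n4)cc3o2)cc(C(C)(C)C)c1O` gives 3000 nM, and compound 3 `CC(C)(C)c1cc(-c2cc(=O)c3ccc(OCCCS(=O)(=O)O)cc3o2)cc(C(C)(C)C)c1O` gives 500 nM. Of the two compounds with a single number, compound 2 stands at the higher one. For the measured compounds named here, the only measured step, a 6.0-fold lower number from compound 2 to compound 3 (0.78 log units; beyond the scatter), is modest but beyond the scatter, and it corresponds to 2-sulfoethyl in place of quinolin-2-yl on a saturated chain carbon bound to an oxygen on an aromatic ring.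

Compound 4 `CC(C)(C)c1cc(-c2cc(=O)c3ccccc3o2)cc(C(C)(C)C)c1O` has not yet been measured. It differs from compound 2 by hydrogen in place of (quinolin-2-yl)methoxy on an aromatic carbon. Going by the values given here, no measured step removes a group from this position altogether; the one step at this place swaps one group for another, and the two entries of compound 1 the several entries of compound 1 in this assay, 3000 nM; 100 nM (2 entries) show that another group at the same place can land anywhere across a wide span. With that measured step being modest, a step of similar size is expected, leaning slightly toward a lower number. Compound 4 is therefore estimated at 2000 nM, with a range from 300 nM to 10000 nM. The estimate for compound 4 means an expected step of a 1.5-fold lower number from compound 2 to compound 4 (0.18 log units; within the scatter).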

Compound 4, half-maximal inhibitory concentration: 3000 nM
Compound 4: the middle estimate sits 1.5-fold (0.18 log units) below what was measured, within the range that was stated.
By their numbers in this assay, from the lowest: compound 3; then compounds 2 and 4 (each within the scatter of the next).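

In this assay, taking away the whole (quinolin-2-yl)methoxy group, with its two aromatic rings and 12 heavy atoms, and leaving only hydrogen gives no change at the digits printed from compound 2 to compound 4 (within the scatter), so at this aromatic carbon the large group and bare hydrogen cannot be told apart on this read-out. The same bare compound now gives the position a baseline, and against it the 3-sulfopropoxy group does stand out: the step back to hydrogen is a 6.0-fold higher number from compound 3 to compound 4 (0.78 log units; beyond the scatter), so the earlier difference between compound 2 and compound 3 comes from the 3-sulfopropoxy group lowering the number, not from the quinoline-bearing group raising it. Compound 1 could be read against this same baseline only if its entries agreed, and they do not: the several entries of compound 1 in this assay, 3000 nM; 100 nM (2 entries)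

Whether the lower number of compound 3 depends on the sulfonic acid itself or on the chain that carries it stays open, since a plain propoxy chain, a longer chain ending in sulfonic acid and a phosphonic acid on the same chain are not among the compounds shown. How an amine at the end of such a chain would read at this position is equally unknown from these compounds.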